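The compounds below may be only part of what the source reports. "The series", "measured", "known", "first", "only" and "open" are said of these compounds alone.

Measured compounds:
compound 1 `COc1ccc(CN(C(=O)CCl)c2cc(OC)c(OC)c(OC)c2)cc1O` with 84 nM
compound 2 `COc1cc(NCc2cccc(O)c2)cc(OC)c1OC` with 57600 nM
compound 3 `COc1ccc(CNc2cc(OC)c(OC)c(OC)c2)cc1Cl` with 46200 nM

Three compounds share a core and were tested in a functional assay on MGC-803 cells (Homo sapiens) for inhibition, read by MTT assay, with a stated time of 48 h; on this read-out lower numbers stand for stronger inhibition and higher numbers for weaker inhibition. In this assay compound 1 gives 84 nM, the lowest number of the three and therefore the strongest inhibition shown. The next compound is compound 3, whose value lies far beyond the scatter from compound 1, and compound 2 lies still further away. Going by the values given here, both of those compounds carry an amine in place of the amide of compound 1, but no single-change step between them is available, so only their values can be compared.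

Compound 4 `C=CC(=O)N(Cc1ccc(OC)c(O)c1)c1cc(OC)c(OC)c(OC)c1` has not yet been measured in this assay. It differs from compound 1 in one place:

vinyl in place of chloromethyl on a carbonyl carbon

Put another way, a (chloromethyl)carbonyl becomes a vinylcarbonyl. Among the compounds with values here, no measured pair shows this change, so its size is uncertain. A modest step toward weaker inhibition is expected, a 2.4-fold higher number from compound 1 to compound 4 (0.38 log units; beyond the scatter), possibly within the scatter. On that basis compound 4 is estimated at 200 nM, with a range from 60 nM to 700 nM.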

Compound 4, half-maximal inhibitory concentration: 62 nM
Compound 4: middle estimate off by 3.2-fold (0.51 log units), on the high side, within the range that was stated.
By their numbers in this assay, from the lowest: compounds 4 and 1 (each within the scatter of the next); then compounds 3 and 2 (each within the scatter of the next).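

In this assay, putting vinyl in place of chloromethyl on a carbonyl carbon gives a 1.4-fold lower number from compound 1 to compound 4 (0.13 log units; within the scatter), so the two compounds cannot be told apart on this read-out. Going by these compounds alone, this is the first single-change comparison at this position, and it shows that inhibition at this level does not depend on the chlorine, since a group without it serves equally well here. Within the data shown here, nothing measured so far accounts for this match.

A plain methyl or a longer chain such as propyl on the same carbonyl carbon is not among the compounds shown, so it remains open whether this level of inhibition needs chloromethyl or vinyl specifically. On these data alone, it also remains open how a change to the other parts of compound 4 would read, such as a methoxy group in place of its hydroxyl.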